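The source may hold more compounds than are shown below. What is called first, only, known or untested is meant among the compounds shown, and "the series" means these compounds.

Working notes on the series. Of the compounds shown here, two have been measured in a functional assay on NCI-H358 cells (Homo sapiens) for antiproliferative activity, read by CCK-8 assay, with a stated time of 72 h; on this read-out higher numbers stand for weaker inhibition of growth and lower numbers for stronger inhibition of growth. Compound 1 `C=C(C(=O)N1CCN(C(=O)Oc2cc3c(Nc4ccc(Cl)c(Cl)c4F)ncnc3cc2OC)[C@H](C)C1)C(F)(F)F` gives 1020 nM. Compound 2 `C#CC(=O)N1CCN(C(=O)Oc2cc3c(Nc4ccc(Cl)c(Cl)c4F)ncnc3cc2OC)[C@H](C)C1` gives 671 nM, the lowest of the two numbers, though the step of a 1.5-fold lower number from compound 1 to compound 2 (0.18 log units; within the scatter) is within the scatter. Compound 3 `C=CC(=O)Oc1cc2c(Nc3ccc(Cl)c(Cl)c3F)ncnc2cc1OC` carries vinyl in place of 4-(ethynylcarbonyl)-2-methylpiperazin-1-yl on a carbonyl carbon. Going by the values given here, no measured step bears on this change; the single step measured concerns a different group on the carbonyl carbon and was itself within the scatter, so it offers no direction for a change of this size. Compound 3 is estimated at 2000 nM, with a range of 500 nM to 8000 nM, an expected step of a 3.0-fold higher number from compound 2 to compound 3 (0.47 log units; beyond the scatter).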

Compound 3, concentration for 50% growth inhibition: 619 nM
For compound 3 the middle estimate is 3.2-fold (0.51 log units) above the measured one, within the range that was stated.
By their numbers in this assay, from the lowest: compounds 3, 2 and 1 (each within the scatter of the next).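

In this assay, vinyl in place of 4-(ethynylcarbonyl)-2-methylpiperazin-1-yl on the carbonyl carbon gives a 1.1-fold lower number from compound 2 to compound 3 (0.04 log units; within the scatter) and so leaves the number unmoved. The earlier step changed only the group at the end of the piperazine; this one removes the whole six-membered ring and its defined stereocentre, and the read-out still stays within the scatter. No evidence is available to explain this result.

Going by these compounds, it remains open whether an amine or a carboxylic acid at this place would move the number beyond the scatter. The same holds for a longer chain in place of vinyl.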